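Aryl variation on the ring nitrogen of the shared core

The source may hold more compounds than are shown below. What is called first, only, known or untested is meant among the compounds shown, and "the series" means these compounds.

Three analogues sharing one core differ only in the aryl group on an aromatic nitrogen. Compound 1 `Cn1c(=O)c(C(=O)Nc2ccc(Oc3ccncc3-c3cccnc3)c(F)c2)nn(-c2ccccc2F)c1=O` gives 6760 nM in a functional assay on MDA-MB-231 cells (Homo sapiens) for cytotoxicity, read by MTT assay, with a stated time of 72 h; a lower number here means a stronger inhibitor, a higher number a weaker inhibitor. Compound 2 `Cn1c(=O)c(C(=O)Nc2ccc(Oc3ccncc3-c3cccnc3)c(F)c2)nn(-c2ccc(Cl)cc2)c1=O` gives 3220 nM in this assay, and compound 3 `Cn1c(=O)c(C(=O)Nc2ccc(Oc3ccncc3-c3cccnc3)c(F)c2)nn(-c2c(Cl)cccc2Cl)c1=O` gives 9690 nM. Compound 3 thus carries the highest number of the three: a 3.0-fold higher number from compound 2 to compound 3 (0.48 log units; beyond the scatter), whereas a 1.4-fold higher number from compound 1 to compound 3 (0.16 log units; within the scatter), so compound 3 and compound 1 cannot be separated.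

The next analogue, compound 4 `Cn1c(=O)c(C(=O)Nc2ccc(Oc3ccncc3-c3cccnc3)c(F)c2)nn(-c2ccc(F)c(Cl)c2)c1=O`, takes the step (3-chloro-4-fluorophenyl in place of 2,6-dichlorophenyl on an aromatic nitrogen). Within the data shown here, two measured steps bear on it. The first is a 3.0-fold higher number from compound 2 to compound 3 (0.48 log units; beyond the scatter), which read backwards says that trading the 2,6-dichlorophenyl for an aryl carrying a single 4-chloro substituent lowers the number. The second is a 2.1-fold lower number from compound 1 to compound 2 (0.32 log units; beyond the scatter), which places the 4-chlorophenyl at the lowest number in the set. Among the measured compounds shown here, compound 4 carries a 3-chloro-4-fluorophenyl, a substitution pattern closer to that of compound 2 than to that of compound 3, although no measured pair tests a halogen in that exact arrangement. A modest downward step is therefore expected: a 2.4-fold lower number from compound 3 to compound 4 (0.38 log units; beyond the scatter). Compound 4 is estimated to give 4000 nM in this assay, with a range from 1500 nM to 10000 nM.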

Compound 4, half-maximal inhibitory concentration: 11300 nM
Compound 4: the middle estimate sits 2.8-fold (0.45 log units) below what was measured; the measured number lies above the stated range.
By their numbers in this assay, from the lowest: compound 2; then compounds 1, 3 and 4 (each within the scatter of the next).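

In this assay the 3-chloro-4-fluorophenyl cannot be separated from the 2,6-dichlorophenyl (a 1.2-fold higher number from compound 3 to compound 4 (0.07 log units; within the scatter)) or from the 2-fluorophenyl (a 1.7-fold higher number from compound 1 to compound 4 (0.22 log units; within the scatter)), so three different halogen patterns on this aromatic nitrogen now read alike. Compound 2 alone stands apart, and the modest new step (a 3.5-fold higher number from compound 2 to compound 4 (0.55 log units; beyond the scatter)) shows that its low number does not carry over to the 3-chloro-4-fluorophenyl, so a chlorine on the aryl is not enough in itself, as compound 3 and compound 4 both show. Nothing shown here explains why the 4-chlorophenyl stands apart from the other three aryl groups.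

Compound 4 differs from compound 2 both in where its chlorine sits and in its added fluorine, so 3-chlorophenyl and 4-fluorophenyl would be needed to tell these two changes apart. Going by these compounds, it also remains open whether the low number of compound 2 is specific to a halogen, or whether an unsubstituted phenyl, or a phenyl carrying a methoxy group, an amine or a carboxylic acid, would fall with compound 2 or with the other three.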